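Trifluoromethyl in Place of Hydrogen on Compound 1

The source may report more compounds than this note shows. Statements on the series, on what has been measured and on what is new or still open speak of the compounds shown alone.

Compound 1 `Cc1cc2c(cc1C)C(Cl)=C(/C=N/NC(=O)c1ccccc1)CCC2` was examined in a functional assay on HeLa cells (Homo sapiens) for inhibition, read by sulforhodamine B assay, with a stated time of 48 h; on this read-out higher numbers stand for weaker inhibition of growth and lower numbers for stronger inhibition of growth. In this assay compound 1 reports only a limit, > 100000 nM. Compound 2 `Cc1ccc(C(=O)N/N=C/C2=C(Cl)c3cc(C)c(C)cc3CCC2)cc1` carries methyl in place of hydrogen on an aromatic carbon of the phenyl; in this assay compound 2 likewise reports only a limit, > 100000 nM. The step that the two limits leave unreadable from compound 1 to compound 2 therefore cannot be sized. Among the compounds with values here, compound 3 `Cc1cc2c(cc1C)C(Cl)=C(/C=N/NC(=O)c1cccnc1)CCC2`, with pyridin-3-yl in place of phenyl on the carbonyl carbon, is the one member with a number: in this assay compound 3 gives 650 nM. The steps of an at least 150-fold lower number from compound 1 to compound 3 (2.18 log units; beyond the scatter) and an at least 150-fold lower number from compound 2 to compound 3 (2.18 log units; beyond the scatter) are the only readable ones, and both are large. Compound 1 thus stands at the limit of > 100000 nM in this assay, at which 2 of the 3 values shown sit, together with compound 2, while compound 3 stands well apart.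

Compound 4 `Cc1cc2c(cc1C)C(Cl)=C(/C=N/NC(=O)c1cccc(C(F)(F)F)c1)CCC2` differs from compound 1 by trifluoromethyl in place of hydrogen on an aromatic carbon, the group sitting on an aromatic carbon of a six-membered aromatic ring of carbon only, meta to a large group. This change keeps the phenyl and adds a substituent to it, the kind of change seen between compound 1 and compound 2, not the exchange of phenyl for pyridin-3-yl seen with compound 3. Compound 4 is therefore expected to remain near the limit, at 100000 nM with a range of 20000 nM to 300000 nM. The step of a number no higher from compound 1 to compound 4 (the limit leaves the size open) is expected to be none beyond the scatter.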

Compound 4, concentration for 50% growth inhibition: 6800 nM
Compound 4: middle estimate off by 15-fold (1.17 log units), on the high side; the whole stated range lies above it.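

Trifluoromethyl in place of hydrogen gives an at least 14-fold lower number from compound 1 to compound 4 (1.16 log units; beyond the scatter) in this assay, so a substituent on an aromatic carbon of this six-membered aromatic ring of carbon only, meta to a large group, can by itself bring the phenyl series off the limit. Within the data shown here, until now, the only member with a number was compound 3, in which the phenyl itself is exchanged for pyridin-3-yl; compound 4 shows that the phenyl can be kept and a number still obtained, so this exchange is not the only single change to compound 1 that yields one. Compound 2, with its added methyl, goes against any general claim for substituents on the phenyl, and it remains with compound 1 at the limit: the limit of > 100000 nM in this assay, at which 2 of the 4 values shown sit.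

Going by these compounds, whether a nitrile, a methoxy group or a chlorine atom at this same place would also give a number remains open, as does whether trifluoromethyl would do so on another aromatic carbon of the phenyl. Also open is what trifluoromethyl would do on the pyridin-3-yl of compound 3, and these values give no reason for the gain seen with compound 4.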